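A few compounds are considered here, and "the series" means these few. Any claim that something is new, unique, unknown or untested is made for them only; others in the source may bear on it.

Series notes. Compound 1 `COc1ccc(C2CC(c3ccccc3)=NN2C2=NC(=O)/C(=C3\C(=O)Nc4ccccc43)S2)cc1` gives 2300 nM in a functional assay on cells (Cancer cell lines, Homo sapiens) for cytotoxicity, read by sulforhodamine B assay, with a stated time of 48 h; on this read-out lower numbers stand for stronger inhibition of growth and higher numbers for weaker inhibition of growth. Compound 2 `O=C1N=C(N2N=C(c3ccccc3)CC2c2ccc(Cl)cc2)S/C1=C1/C(=O)Nc2ccccc21` gives 230 nM in this assay, and compound 3 `CN(C)c1ccc(C2CC(c3ccccc3)=NN2C2=NC(=O)/C(=C3\C(=O)Nc4ccccc43)S2)cc1` gives 1220 nM in this assay, the second highest number of the three measured: a 1.9-fold lower number from compound 1 to compound 3 (0.28 log units; within the scatter), whereas a 10-fold lower number from compound 1 to compound 2 (1.00 log units; beyond the scatter) and a 5.3-fold higher number from compound 2 to compound 3 (0.72 log units; beyond the scatter). Compound 4 `CN(C)c1ccc(C2CC(c3ccccc3)=NN2C2=NC(=O)/C(=C3\C(=O)Nc4ccc(Cl)cc43)S2)cc1` differs from compound 3 by chloro in place of hydrogen on an aromatic carbon. For the measured compounds named here, no measured step concerns this change directly; the only earlier chloro step, a 10-fold lower number from compound 1 to compound 2 (1.00 log units; beyond the scatter), was made elsewhere in the structure and is a weak precedent at best. A step of a 1.7-fold lower number from compound 3 to compound 4 (0.24 log units; within the scatter) in this assay is therefore expected, toward a lower number but small, possibly not beyond the scatter. Compound 4 is estimated at 700 nM in this assay, within the range 250 nM to 2000 nM.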

Compound 4, concentration for 50% growth inhibition: 240 nM
Beside the measured number, compound 4's estimate is 2.9-fold (0.46 log units) above it, outside the stated range (below it).
By their numbers in this assay, from the lowest: compounds 2 and 4 (each within the scatter of the next); then compounds 3 and 1 (each within the scatter of the next).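

Chloro in place of hydrogen on the six-membered aromatic ring of the fused system gives a 5.1-fold lower number from compound 3 to compound 4 (0.71 log units; beyond the scatter), so this ring, unchanged across compounds 1 to 3, also affects growth inhibition. The earlier steps shown here varied only a substituent elsewhere in the structure. No available evidence explains this step.

Open, going by these compounds, is whether a smaller halogen such as fluoro, or a group such as an amine or a carboxylic acid, would serve at this place. Also open, on these data alone, is whether the chloro step here carries over to compound 1 or compound 2.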